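This account rests on a few compounds, and the source may have more. Where it says the series, first, only, none or still open, it means among the compounds named here.

Working notes on the series, EP3 antagonism.

Three compounds carry the shared core of compound 1 `C/C(=C1/OC(=O)NC1=O)C(c1ccc(-c2ccc3cccc(F)c3c2)[nH]c1=O)C(C)C`. In a functional assay on CHO cells for antagonist activity at prostaglandin E2 receptor EP3 subtype (Homo sapiens), read by cAMP accumulation, with a stated time of 30 min (a lower number here means a stronger inhibitor, a higher number a weaker inhibitor), compound 1 gives 39 nM, the second highest of the three numbers. Compound 3 `O=C1NC(=O)/C(=C/C(c2ccc(-c3ccc4cccc(F)c4c3)[nH]c2=O)C2CC2)O1` gives 33 nM in this assay, which lies within the scatter of the number for compound 1. Compound 2 `CC(C)/C(=C1\C(=O)NC(=O)N1C)c1ccc(-c2ccc3cccc(F)c3c2)[nH]c1=O` gives 350 nM in this assay, a number beyond the scatter from compound 1 and the weakest of the set.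

Compound 4 `CC(C)C(/C=C1/C(=O)NC(=O)N1C)c1ccc(-c2ccc3cccc(F)c3c2)[nH]c1=O` has not been measured. It differs from compound 1 in one place: a group of 9 heavy atoms (5 carbon, 2 nitrogen, 2 oxygen; one five-membered non-aromatic ring with 2 hetero atoms) in place of a group of 9 heavy atoms (5 carbon, 1 nitrogen, 3 oxygen; one five-membered non-aromatic ring with 2 hetero atoms), on a saturated chain carbon bound to an aromatic carbon and a saturated chain carbon. The entering group, with one five-membered non-aromatic ring with 2 hetero atoms and 2 nitrogen in place of 1 nitrogen and 3 oxygen, is the same kind of ring that compound 2 carries, and compound 2 gives 350 nM. Compound 4 keeps the 3 double bonds outside aromatic rings that compound 1 has, so a smaller loss than compound 2 shows is expected.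

The estimated step from compound 1 to compound 4 is a 2.6-fold higher number from compound 1 to compound 4 (0.41 log units; beyond the scatter), a moderate rise expected in this assay. Compound 4 is expected to give about 100 nM in this assay, in the range 35 nM to 300 nM.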

Compound 4, half-maximal inhibitory concentration: 11 nM
Estimate against measurement, compound 4: 9.1-fold (0.96 log units) above; the measured number lies below the stated range.
By their numbers in this assay, from the lowest: compound 4; then compounds 3 and 1 (each within the scatter of the next); then compound 2.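

On a saturated chain carbon bound to an aromatic carbon and a saturated chain carbon, the exchange of rings in this assay gives a 3.5-fold lower number from compound 1 to compound 4 (0.55 log units; beyond the scatter), so the group with 2 nitrogen is compatible with a stronger inhibitor here than the group with 3 oxygen. Going by these compounds alone, the count of double bonds outside aromatic rings stays at 3 across this step, while the hydrogen-bond acceptors go from 3 to 2, and this is the only step in the set that changes one place alone. No measurement bears on what lies behind the step.

The compounds shown leave open whether a carboxylic acid or an amine on this same carbon, in place of either ring group, would keep a number in this range. They also leave open whether the step holds on other prostaglandin receptor subtypes.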